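A few compounds are considered here, and "the series" means these few. Any claim that something is new, unique, unknown or untested is made for them only; others in the source may bear on it.

Compound 1 `CCOc1ccc(NC(=O)c2cc3cc(Br)ccc3oc2=O)cc1` gives 16800 nM
Compound 2 `O=C(N/N=C/c1cccnc1)c1cc2ccc(O)cc2oc1=O` gives 2530 nM

In a functional assay on PANC-1 cells (Homo sapiens) for antiproliferative activity, read by fluorescence and resazurin assay, with a stated time of 48 h (on this read-out higher numbers stand for weaker inhibition and lower numbers for stronger inhibition), compound 2 gives 2530 nM as the lower of the two numbers, and compound 1 at 16800 nM lies beyond the scatter above it. Compound 3 `O=C(N/N=C/c1cccnc1)c1cc2ccccc2oc1=O` carries hydrogen in place of hydroxy on an aromatic carbon of compound 2 (hydrogen in place of hydroxy on an aromatic carbon). Within the data shown here, no measured pair shows this change, so the expectation is loose. The expected step in this assay is small and toward weaker inhibition (a 1.6-fold higher number from compound 2 to compound 3 (0.20 log units; within the scatter)) and does not go beyond the scatter. In this assay compound 3 is estimated at 4000 nM (expected range 1500 nM to 12000 nM).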

Compound 3, half-maximal inhibitory concentration: 15300 nM
For compound 3 the middle estimate is 3.8-fold (0.58 log units) below the measured one; the whole stated range lies below it.
By their numbers in this assay, from the lowest: compound 2; then compounds 3 and 1 (each within the scatter of the next).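

In this assay, among these compounds, the hydroxy on this aromatic carbon is the first single change that can be read, and a 6.0-fold higher number from compound 2 to compound 3 (0.78 log units; beyond the scatter) shows that replacing it with hydrogen weakens inhibition beyond the scatter. The position therefore responds to this change, at least with the pyridine-bearing side chain shared by compound 2 and compound 3. No measurement shown explains the step. From the compounds shown here alone, whether a methoxy group or an amine on the same aromatic carbon would give numbers like that of compound 2 remains open. So does whether the hydroxy has the same effect in the anilide of compound 1.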